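The source may report more compounds than this note shows. Statements on the series, on what has been measured and on what is new or still open speak of the compounds shown alone.

Working notes on the hydroxamic acid series.

Of the compounds shown here, two have numbers so far. Compound 1 `O=C(CCC1=CCN(CCCc2ccc(Cl)cc2)C1=O)NO` gives 5100 nM in a functional assay on HCT-15 cells (Homo sapiens) for inhibition, read by sulforhodamine B assay; a lower number here means a stronger inhibitor of growth, a higher number a weaker inhibitor of growth; compound 2 `Cc1ccc(CN2CC=C(CCC(=O)NO)C2=O)cc1` gives 4720 nM in the same assay. Compound 1 therefore carries the higher of the two numbers, but the gap to compound 2 is within the scatter, so the two read as the same within this assay and neither can be called the stronger inhibitor of growth.

Compound 3 `CC(C)(C)c1ccc(CCCN2CC=C(CCC(=O)NO)C2=O)cc1` keeps the core of compound 1 and changes only the substituent on the six-membered aromatic ring of carbon only, para to a large group: tert-butyl in place of chloro on an aromatic carbon. Among the compounds with values here, nothing measured so far tells how this position responds, as compound 2 differs from compound 1 in more than one place.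

With no shown step to lean on, the expectation is a step from compound 1 to compound 3 of a 1.1-fold lower number from compound 1 to compound 3 (0.05 log units; within the scatter), that is, no move beyond the scatter in either direction. Compound 3 is accordingly estimated at 4500 nM, with a range from 1500 nM to 13000 nM.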

Compound 3, concentration for 50% growth inhibition: 5100 nM
Compound 3: the middle estimate sits 1.1-fold (0.05 log units) below what was measured, and the stated range covers the measured number.
By their numbers in this assay, from the lowest: compounds 2, 1 and 3 (each within the scatter of the next).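

In this assay, within the data shown here, tert-butyl in place of chloro on an aromatic carbon of the six-membered aromatic ring of carbon only, para to a large group, gives no change at the digits printed from compound 1 to compound 3 (within the scatter), and this is the first reading of this position with the rest of the structure held fixed. Within this single exchange, growth inhibition does not respond to the substituent: chloro and tert-butyl read as the same, although they differ in heavy-atom count, and this finding applies to these two groups alone. Nothing at hand bears on why the number stays flat at this position.

The compounds shown leave open whether the position remains this unresponsive with an amine, a carboxylic acid or a methoxy group in place of chloro. Also open, as far as these compounds go, is how a longer chain between the aromatic ring and the shared core would read as a single change, and whether any change at either place can move the number beyond the scatter.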